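Moving the hydroxyl around the pyridine of an amide

The source may hold more compounds than are shown below. What is called first, only, known or untested is meant among the compounds shown, and "the series" means these compounds.

Three compounds share one core and differ only in the hydroxypyridine attached at an amide-type nitrogen. Compound 1 `CN1C(C(=O)Nc2ccc(O)cn2)=C(O)c2ccccc2S1(=O)=O` gives 15% in a functional assay on the whole organism for inhibition, with Rattus norvegicus as the target, with a stated time of 4 h, at a dose of 10 mg/kg by the oral route; a higher number here means more inhibition at the dose given (going by the name of the read-out), a lower number less inhibition. Compound 2 `CN1C(C(=O)Nc2ncccc2O)=C(O)c2ccccc2S1(=O)=O` gives 13% in this assay, and compound 3 `CN1C(C(=O)Nc2cccc(O)n2)=C(O)c2ccccc2S1(=O)=O` gives 31% in this assay. Compound 3 therefore stands highest of the three: the step of a number 16 percentage points higher from compound 1 to compound 3 (beyond the scatter) and the step of a number 18 percentage points higher from compound 2 to compound 3 (beyond the scatter) both lie beyond the scatter, while the step of a number 2 percentage points lower from compound 1 to compound 2 (within the scatter) does not.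

Compound 4 `CN1C(C(=O)Nc2cc(O)ccn2)=C(O)c2ccccc2S1(=O)=O` is the next isomer of this series. The change is 4-hydroxypyridin-2-yl in place of 6-hydroxypyridin-2-yl on an amide-type nitrogen. The bearing steps are the three already seen, in which shifting the hydroxyl produced either no real change or a modest rise. Two of three placements gave low inhibition, so a drop from compound 3 seems the more likely outcome, expected as a number 12 percentage points lower from compound 3 to compound 4 (beyond the scatter) in this assay. Compound 4 is estimated to give 19%, with a range from 8% to 32%.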

Compound 4, a percentage reported as inhibition, in the whole organism at one dose (the size of the read-out at that dose, not a potency): 10%
The estimate for compound 4 lay 9 percentage points above the measured number; low and high end bracket the measured number.
By their numbers in this assay, from the lowest: compounds 4, 2 and 1 (each within the scatter of the next); then compound 3.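

In this assay, 4-hydroxypyridin-2-yl in place of 6-hydroxypyridin-2-yl on the amide-type nitrogen gives a number 21 percentage points lower from compound 3 to compound 4 (beyond the scatter), so this new placement of the hydroxyl does not keep the higher number of compound 3. The other two steps, a number 3 percentage points lower from compound 2 to compound 4 (within the scatter) and a number 5 percentage points lower from compound 1 to compound 4 (within the scatter), put compound 4 level with compound 2 and compound 1, which leaves the 6-hydroxypyridin-2-yl group of compound 3 as the only one of the four isomers that stands apart. Nothing available here explains why this one placement differs.

Every compound shown carries a hydroxyl on the pyridine, so it remains open whether an amine or a carboxylic acid in its place on the 6-hydroxypyridin-2-yl group would hold the number of compound 3. Each figure is also a reading at one dose, which leaves open how these isomers would compare at other doses.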